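Adding a bromobenzyl group to a weakly active chromone

The source may report more compounds than this note shows. Statements on the series, on what has been measured and on what is new or still open speak of the compounds shown alone.

Of the compounds shown here, two of the same shared core have been measured in a functional assay on HUVEC cells (Homo sapiens) for antiproliferative activity, read by MTT assay, with a stated time of 24 h; on this read-out higher numbers stand for weaker inhibition and lower numbers for stronger inhibition. Compound 1, `COc1cc(OC)c(-c2coc3cc(OCc4ccccc4)ccc3c2=O)cc1OC`, carries a benzyl group on the oxygen of the core and gives 9750 nM. Compound 2, `COc1ccc2c(=O)c(-c3cc(OC)c(OC)cc3OC)coc2c1`, has a hydrogen in place of that phenyl on the saturated chain carbon bound to the oxygen. For compound 2 the result is only a limit of the assay, > 10000 nM. The change from the benzyl to the methoxy group therefore reads as an at least 1.0-fold higher number from compound 1 to compound 2 (0.01 log units; that floor lies within the scatter), with the caveat that one of the two values sits at the limit of > 10000 nM in this assay, at which 1 of the 2 values shown sits, so compound 2 may in truth lie well beyond the number shown.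

Compound 3, `COc1cc(OC)c(-c2coc3cc(OCc4ccc(Br)cc4)ccc3c2=O)cc1OC`, is the not yet measured member. It differs from compound 2 by 4-bromophenyl in place of hydrogen on a saturated chain carbon bound to an oxygen on an aromatic ring. Within the data shown here, this is close to the reverse of the single step measured, with a bromine added at the far end of the entering ring. Since going from phenyl to hydrogen moved the number little or not at all, the reverse is expected to move it little as well, giving an estimated step of an at least 1.2-fold lower number from compound 2 to compound 3 (0.09 log units; that floor lies within the scatter). Compound 3 is estimated at 8000 nM, between 3000 nM and 25000 nM, near compound 1.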

Compound 3, half-maximal inhibitory concentration: > 10000 nM
Compound 3: no number, only a limit; the forecaster's own chance of this, stated with the estimate: 40%; at least 1.2-fold (0.09 log units) between middle value and limit.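

In this assay compound 3 gives > 10000 nM, which is a limit of the assay and not a number. Putting a bromo in place of hydrogen on an aromatic carbon of the benzyl group gives an at least 1.0-fold higher number from compound 1 to compound 3 (0.01 log units; that floor lies within the scatter), so this change shows no sign of a lower number, and the 4-bromobenzyl group on this oxygen does not bring the compound to a measured value. Steps from compound 2 to compound 3 cannot be read, because both ends are limits and only compound 1 keeps an actual number: the limit of > 10000 nM in this assay, at which 2 of the 3 values shown sit.

Going by these compounds, how far compound 2 and compound 3 truly lie beyond the limit stays open, and so does whether the bromo group makes any real difference to the benzyl group at this position. Also open, on these data alone, is whether an amine or a carboxylic acid carried on this oxygen, or a longer chain in place of the benzyl group, would give a number clearly lower than that of compound 1, 9750 nM, on the same shared core.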